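Bromo for chloro on the arylpiperazine: compound 4

The source may hold more compounds than are shown below. What is called first, only, known or untested is meant among the compounds shown, and "the series" means these compounds.

Measured so far in an assay on CHO cells for displacement of a labelled ligand from D(4) dopamine receptor (Homo sapiens), read by radioligand binding; a higher number here means a weaker inhibitor, a lower number a stronger inhibitor:
- compound 1, `COc1ccccc1N1CCN(CCCNC(=O)NN(Cc2ccccc2)c2ccc(Cl)cc2)CC1`, gives 2.9 nM
- compound 2, `COc1ccccc1N1CCN(CCCNC(=O)NN(Cc2ccccc2)c2ccc(Br)cc2)CC1`, gives 3.4 nM
- compound 3, `O=C(NCCCN1CCN(c2ccc(Cl)cc2)CC1)NN(Cc1ccc(F)cc1)c1ccccc1`, gives 17 nM

Compound 1 and compound 2 differ in one place: bromo in place of chloro on an aromatic carbon. The step is a 1.2-fold higher number from compound 1 to compound 2 (0.07 log units; within the scatter), so the two halogens are not told apart in this assay.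

Compound 3 sits on a different core; the difference between the core of compound 3 and the core of compound 1 is not broken down here. Its value in this assay is the highest of the three, beyond the scatter from both compound 1 and compound 2.

Compound 4, `O=C(NCCCN1CCN(c2ccc(Br)cc2)CC1)NN(Cc1ccc(F)cc1)c1ccccc1`, is not yet measured. It differs from compound 3 by bromo in place of chloro on an aromatic carbon, with the same place as in the first pair, so this is the same change made on the other core. Since the step from compound 1 to compound 2 was a 1.2-fold higher number from compound 1 to compound 2 (0.07 log units; within the scatter), the expectation for compound 4 is a step of about a 1.2-fold higher number from compound 3 to compound 4 (0.07 log units; within the scatter) from compound 3, within the scatter. Compound 4 is therefore estimated at 20 nM in this assay, between 8 nM and 50 nM.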

Compound 4, inhibition constant: 46 nM
Beside the measured number, compound 4's estimate is 2.3-fold (0.36 log units) below it; measured number inside the range.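

On the second core, bromo in place of chloro gives a 2.7-fold higher number from compound 3 to compound 4 (0.43 log units; beyond the scatter) in this assay, a modest step when read alone. Set beside the same change on the first core, it does not separate from the earlier step: the same change on two cores in this assay, a 1.2-fold higher number (0.07 log units; within the scatter) from compound 1 to compound 2 and a 2.7-fold higher number (0.43 log units; beyond the scatter) from compound 3 to compound 4, 2.3-fold (0.36 log units) apart, within the scatter of two such steps. The two pairs therefore give no firm sign that the outcome of this change depends on the core, but with one pair per core they do not show that it carries over unchanged, and they cannot settle whether the second core is truly less tolerant of bromo.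

Still open, from the compounds shown here alone, is whether iodo, nitrile or trifluoromethyl in the same place would give steps that agree on both cores, which would test the comparison over more than one halogen swap. Also open, going by these compounds, is whether the same agreement would hold on cores with a longer chain between the urea and the basic amine.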